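A few compounds are considered here, and "the series" means these few. Any claim that something is new, unique, unknown or untested is made for them only; others in the source may bear on it.

Compound 1 `CCCCCC(CCO)n1cnc2c(OC)ncnc21`: > 50000 nM (a limit)
Compound 2 `CCCCCCC(CCO)n1cnc2c(OC)ncnc21`: > 50000 nM (a limit)
Compound 3 `CCCCCCCCCC(CCO)n1cnc2c(OC)ncnc21`: 2530 nM

All three were tested in a functional assay on HCT-116 cells (Homo sapiens) for antiproliferative activity, read by MTT assay, with a stated time of 48 h; on this read-out lower numbers stand for stronger inhibition and higher numbers for weaker inhibition. Compound 1 and compound 2 give only a limit, as the limit of > 50000 nM in this assay, at which 2 of the 3 values shown sit, records. Going by the values given here, compound 3 gives 2530 nM, the only true number so far.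

Compound 4 `CCCCCCCCCCCC(CCO)n1cnc2c(OC)ncnc21` extends the chain of compound 3: ethyl in place of hydrogen on a saturated chain carbon, ten or more bonds along the chain from an aromatic nitrogen.

Among the compounds with values here, two measured steps bear on this change, an at least 19-fold lower number from compound 1 to compound 3 (1.29 log units; beyond the scatter) and an at least 19-fold lower number from compound 2 to compound 3 (1.29 log units; beyond the scatter), and both are large. The third, a step that the two limits leave unreadable from compound 1 to compound 2, cannot be read. Longer chains therefore point towards lower numbers, but ethyl is a smaller addition than propyl or butyl, so a moderate move in the same direction seems likely. The expected step is a 2.5-fold lower number from compound 3 to compound 4 (0.40 log units; beyond the scatter). For compound 4 the estimated value is 1000 nM, with an expected range from 250 nM to 5000 nM.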

Compound 4, half-maximal inhibitory concentration: 8230 nM
Estimate against measurement, compound 4: 8.2-fold (0.92 log units) below, and the stated range ends below it.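

The gain from a longer chain does not continue at this position: adding ethyl gives a 3.3-fold higher number from compound 3 to compound 4 (0.51 log units; beyond the scatter), so compound 3 has the lowest number shown. The longest chain still keeps an advantage over the two shortest, with an at least 6.0-fold lower number from compound 2 to compound 4 (0.78 log units; beyond the scatter) and an at least 6.0-fold lower number from compound 1 to compound 4 (0.78 log units; beyond the scatter). Compound 1 and compound 2 give a limit rather than a number, so these two steps have no exact size: the limit of > 50000 nM in this assay, at which 2 of the 4 values shown sit.

From the compounds shown here alone, whether a longer chain would raise the number further, or a chain carrying an amine would change it, stays open.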